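Phenyl in place of nitrophenyl: a sulfonamide amide series

The compounds below may be only part of what the source reports. "The series", "measured", "known", "first", "only" and "open" are said of these compounds alone.

Measured compounds:
compound 1, `CC(=O)c1ccc(NC(=O)CN(C(=O)c2ccccc2)S(=O)(=O)c2ccc(C)cc2)cc1`, 18.1%
compound 2, `CC(=O)c1ccc(NC(=O)CN(C(=O)c2ccccc2)S(=O)(=O)c2ccc([N+](=O)[O-])cc2)cc1`, 20.6%

Of the compounds shown here, two have been measured in a functional assay for inhibition, read by spectrophotometry, with a stated time of 20 min, tested at 2 mg/mL; a higher number here means a stronger effect of the compound at the concentration tested, a lower number a weaker effect. Compound 1, `CC(=O)c1ccc(NC(=O)CN(C(=O)c2ccccc2)S(=O)(=O)c2ccc(C)cc2)cc1`, gives 18.1%. Compound 2, `CC(=O)c1ccc(NC(=O)CN(C(=O)c2ccccc2)S(=O)(=O)c2ccc([N+](=O)[O-])cc2)cc1`, gives 20.6%. The two differ only in the group on one aromatic carbon, nitro in place of methyl, and the step of a number 2.5 percentage points higher from compound 1 to compound 2 (within the scatter) lies within the scatter. Compound 2 therefore stands beside compound 1 rather than apart from it; the two numbers cannot be told apart.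

Compound 3, `CC(=O)c1ccc(NC(=O)CN(C(=O)c2ccccc2)S(=O)(=O)c2ccccc2)cc1`, is not yet measured. It differs from compound 2 in one place: hydrogen in place of nitro on an aromatic carbon. Going by the values given here, the only measured step, the one from compound 1 to compound 2, changed the same aromatic carbon and moved the read-out by a number 2.5 percentage points higher from compound 1 to compound 2 (within the scatter), a change within the scatter. Among the compounds with values here, no measured step bears on the removal of a group at this position itself, so the expectation rests on that one step alone. Compound 3 is expected to give about 18%, with a range from 8% to 28%. The expected step from compound 2 to compound 3 is a number 2.6 percentage points lower from compound 2 to compound 3 (within the scatter), that is, no change beyond the scatter.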

Compound 3, a percentage reported as inhibition, at one concentration (the size of the read-out at that concentration, not a potency): 40.5%
Estimate against measurement, compound 3: 22.5 percentage points below, and the stated range ends below it.
By their numbers in this assay, from the lowest: compounds 1 and 2 (each within the scatter of the next); then compound 3.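

Going by these compounds alone, the earlier step between methyl and nitro suggested that this aromatic carbon, para to a large group, had little bearing on the read-out, but that step compared only two substituted compounds. In this assay, the change from 4-nitrophenyl to phenyl gives a number 19.9 percentage points higher from compound 2 to compound 3 (beyond the scatter), and hydrogen in place of methyl on the same carbon gives a number 22.4 percentage points higher from compound 1 to compound 3 (beyond the scatter), so the two groups, which cannot be told apart from each other, both stand clearly apart from hydrogen in this series of three compounds. No measurement shown here explains the difference between hydrogen and these two groups, so the result can be stated only as an observation about the read-out.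

The compounds shown leave open whether the higher read-out belongs to hydrogen alone or whether other groups on this carbon, such as a fluorine atom, a methoxy group, an amine or a carboxylic acid, would fall with methyl and nitro or with hydrogen. They also leave open whether the same order would hold at other concentrations, since each number is a read-out at a single concentration and not a potency.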